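The compounds below may be only part of what the source reports. "The series", "measured", "known", "first", "only" and "open" are said of these compounds alone.

Measured so far in an assay on L cells for inhibition of Protein-serine O-palmitoleoyltransferase porcupine (Mus musculus), read by reporter gene assay, with a stated time of 24 h; on this read-out lower numbers stand for an effect already at smaller amounts and higher numbers for an effect only at larger amounts of compound:
compound 1 `O=C(CNC(=O)c1nn(-c2ccccc2)c(=O)c2ccccc12)Nc1nc2ccc(Cl)cc2s1` gives 30 nM
compound 2 `O=C(CSc1nc2c(c(=O)n1-c1ccccc1)SCC2)Nc1ccc(-c2ccccc2)cc1` gives 0.75 nM
compound 3 `COc1ccc2nc(NC(=O)CNC(=O)c3nn(-c4ccccc4)c(=O)c4ccccc34)sc2c1` gives 210 nM

Compound 2 holds the lowest number of the three; compound 1 is the nearest and compound 3 the furthest, both gaps beyond the scatter. Compound 4 `O=C(CSc1nc2c(c(=O)n1-c1ccccc1)SCC2)Nc1ccc(-c2cccnc2)cc1` differs from compound 2 in one place: pyridin-3-yl in place of phenyl on an aromatic carbon. For the measured compounds named here, the only single-point step measured, a 7.0-fold higher number from compound 1 to compound 3 (0.85 log units; beyond the scatter), concerns a different core and a different pair of groups, so it does not bear on this change, and no step on the core of compound 2 is known. Without a comparable precedent, the step in this assay is expected to be small, within the scatter or a modest rise. For compound 4 the estimate is 1.5 nM (0.4 nM to 6 nM), which is expected to mean a 2.0-fold higher number from compound 2 to compound 4 (0.30 log units; within the scatter).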

Compound 4, half-maximal effective concentration: 0.45 nM
Compound 4: middle estimate off by 3.3-fold (0.52 log units), on the high side; the range from low to high includes it.
By their numbers in this assay, from the lowest: compounds 4 and 2 (each within the scatter of the next); then compound 1; then compound 3.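

For the compounds shown here, on the core of compound 2, this is the first step read at this position: in this assay it gives a 1.7-fold lower number from compound 2 to compound 4 (0.22 log units; within the scatter) for pyridin-3-yl in place of phenyl. An aromatic ring carbon can therefore give way to nitrogen at this place, para to a large group, with the two compounds remaining within the scatter of each other, even though the entering group counts one hydrogen-bond acceptor and the leaving group none. Nothing available bears on why these numbers lie so close.

Still open, on these data alone, is whether pyridin-2-yl or pyridin-4-yl at the same place would match pyridin-3-yl. Also open, as far as these compounds go, is how an amine or a carboxylic acid on this ring would read.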